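Moving the fluorine on the phenyl of a piperazine amine

A few compounds are considered here, and "the series" means these few. Any claim that something is new, unique, unknown or untested is made for them only; others in the source may bear on it.

Among the compounds with values here, compound 2 `Nc1scc(CN2CCN(c3cccc(F)c3)CC2)c1C(=O)c1ccc(Cl)cc1` is the lower of the two numbers so far in a functional assay on CHO cells with adenosine receptor A1 (Homo sapiens) as the target, read by cAMP accumulation and immunoassay, with a stated time of 6 min, tested at 1 uM; a higher number here means a weaker effect of the compound at the concentration tested, a lower number a stronger effect: compound 2 gives -86%, while compound 1 `Nc1scc(CN2CCN(c3ccc(OC(F)(F)F)cc3)CC2)c1C(=O)c1ccc(Cl)cc1` gives -51%. Within the data shown here, the one measured step, a number 35 percentage points lower from compound 1 to compound 2 (beyond the scatter), is large and goes beyond the scatter, but it swaps one group for another of a different kind. Compound 3 `Nc1scc(CN2CCN(c3ccccc3F)CC2)c1C(=O)c1ccc(Cl)cc1` differs from compound 2 only in that the two have the same atoms joined differently: 2-fluorophenyl in place of 3-fluorophenyl on an amine nitrogen in a ring. Among the measured compounds shown here, no measured pair shows what moving the fluorine around the ring does on its own, so the step from compound 1 to compound 2 bears on it only loosely, as a sign that the group on this ring nitrogen matters. With that, the expectation is a step within the scatter, or at most a small one, and since compound 2 already stands lowest, any drift is expected to be upward rather than downward. Compound 3 is therefore estimated at -76% in this assay, within -100% to -48%, which is expected to mean a step of a number 10 percentage points higher from compound 2 to compound 3 (within the scatter).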

Compound 3, a percentage reported as activity, at one concentration (the size of the read-out at that concentration, not a potency): -9.2%
Compound 3: the middle estimate sits 66.8 percentage points below what was measured; the measured number lies above the stated range.
By their numbers in this assay, from the lowest: compound 2; then compound 1; then compound 3.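

With the same atoms and the same counts of donors and acceptors on both sides, moving one fluorine around the phenyl gives a number 76.8 percentage points higher from compound 2 to compound 3 (beyond the scatter) in this assay, so on this ring nitrogen the place of a single fluorine can matter as much as exchanging one whole group for another. The second new step, a number 41.8 percentage points higher from compound 1 to compound 3 (beyond the scatter), shows that a fluorophenyl is not better than 4-(trifluoromethoxy)phenyl as such: 3-fluorophenyl in compound 2 stands on one side of compound 1 and 2-fluorophenyl in compound 3 on the other, leaving compound 3 with the weakest effect of the three. Nothing available explains why the two fluorine placements differ so sharply.

Going by these compounds, it stays open whether this drop belongs to fluorine in particular or would come with any group in that place, a question that 2-chlorophenyl or 2-methoxyphenyl on the same nitrogen would address. An unsubstituted phenyl there would also show whether 3-fluorophenyl strengthens the effect, 2-fluorophenyl weakens it, or both, as the pair alone gives only the difference.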